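Chloro for amino on the benzyl ring of compound 2

The source may report more compounds than this note shows. Statements on the series, on what has been measured and on what is new or still open speak of the compounds shown alone.

The three measured compounds were all tested in a toxicity assay on NIH3T3 cells (Mus musculus) for cytotoxicity, read by resazurin assay (a higher number here means that more compound is needed for the effect, a lower number that less compound is needed), and none of them gave a number. Compound 1, `c1ccc(Cn2cncc2CNc2cccc(-c3ccccc3)c2)cc1`, reached only the limit > 750 nM, which is a limit of the assay and not a number. Compound 3, `O=C(c1ccc(NCc2cncn2Cc2ccc(-c3ccccc3)cc2)cc1-c1ccccc1)N1CCCCC1`, stopped at the limit > 1000 nM, again a limit rather than a number. Compound 2, `COC(=O)c1ccc(NCc2cncn2Cc2ccc(N)cc2)cc1-c1ccccc1`, stands at > 10000 nM, a limit of the assay and not a number, so its standing among the three can only be described as sitting at the limit of > 10000 nM in this assay, at which 1 of the 3 values shown sits.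

The step from compound 2 leads to compound 4, `COC(=O)c1ccc(NCc2cncn2Cc2ccc(Cl)cc2)cc1-c1ccccc1`, where the change is chloro in place of amino on an aromatic carbon. Within the data shown here, no step between two measured compounds is available to set a scale for this change in this assay, and every value shown is a limit. He therefore expects no step beyond the usual scatter, and expects the step of a number no higher from compound 2 to compound 4 (the limit leaves the size open) to be small. For compound 4 he estimates 10000 nM, in a range of 4000 nM to 30000 nM, most likely reported again as a limit.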

Compound 4, half-maximal effective concentration: 25000 nM
The estimate for compound 4 lay 2.5-fold (0.40 log units) below the measured number, within the range that was stated.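

No step from compound 2 to compound 4 can be read in this assay, because compound 2 stands at a limit of the assay and not at a number: the limit of > 10000 nM in this assay, at which 1 of the 4 values shown sits.

The compounds shown leave open whether chloro in place of amino on an aromatic carbon changes the number at all, and by how much.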